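This account rests on a few compounds, and the source may have more. Where it says the series, first, only, none or still open, it means among the compounds named here.

Of the compounds shown here, two have been measured so far in a functional assay on THP-1 cells (Homo sapiens) for cytotoxicity, read by MTT assay, with a stated time of 2 days; a higher number here means a weaker inhibitor, a lower number a stronger inhibitor. Within the data shown here, compound 1 `COc1ccc2nc(-c3ccc(N=C(NC4CCCCC4)NC4CCCCC4)cc3)sc2c1` is the only one that gives a number: in this assay compound 1 gives 3100 nM. Compound 2 `COc1ccc2nc(-c3ccc(NC(=O)NCc4ccccc4)cc3)sc2c1`, which carries a benzylamino group on the carbonyl carbon, is reported in this assay only as a limit, > 50000 nM, not as a number. Among the measured compounds shown here, one of the two values sits at that limit, (the limit of > 50000 nM in this assay, at which 1 of the 2 values shown sits), so compound 2 stands at the weak end of what this assay can report, with no measured step leading to it.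

Compound 3 `COc1ccc2nc(-c3ccc(NC(=O)C4CC4)cc3)sc2c1` differs from compound 2 in one place: cyclopropyl in place of benzylamino on a carbonyl carbon. The change shortens the amide side chain to a small ring of three carbon atoms, and the single remaining hydrogen-bond donor on that side belongs to the amide-type nitrogen. For the measured compounds named here, with compound 2 already at the limit, the only step that could be seen is a gain in strength, and the data give no reason to expect one. Compound 3 is therefore expected to remain about where compound 2 stands, with an expected step that the limit leaves unreadable from compound 2 to compound 3 that does not exceed the usual scatter. The estimate for compound 3 in this assay is 60000 nM, within 15000 nM to 250000 nM, and most likely it will again be reported only as a limit.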

Compound 3, half-maximal inhibitory concentration: > 50000 nM
Compound 3: a limit, no number; the forecaster's own chance of this, stated with the estimate: 70%; the middle value lies beyond the limit too.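

Compound 2 and compound 3 are both reported only as limits in this assay, not as numbers, so no step between them can be read: the limit of > 50000 nM in this assay, at which 2 of the 3 values shown sit.

The compounds shown leave open how strong compound 2 and compound 3 really are, and so whether cyclopropyl in place of benzylamino on a carbonyl carbon changes anything in this assay.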